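The compounds below may be only part of what the source reports. "The series", "measured", "known", "first", "only" and "open" are said of these compounds alone.

Measured compounds in an ADME assay on Vero cells (Chlorocebus sabaeus) for cytotoxicity, read by MTT assay, with a stated time of 48 h; a lower number here means a stronger inhibitor, a higher number a weaker inhibitor:
compound 1 `CN(Cc1ccc2c(c1)OCCO2)c1nc(=O)c2cc(C(F)(F)F)cc([N+](=O)[O-])c2o1`, 9.27 ug/mL
compound 2 `O=c1nc(NCc2ccccc2)oc2c([N+](=O)[O-])cc(C(F)(F)F)cc12`, 25.4 ug/mL
compound 3 `COc1ccc(CNc2nc(=O)c3cc(C(F)(F)F)cc([N+](=O)[O-])c3o2)cc1OC`, 29.2 ug/mL

Compound 3 gives the highest of the three numbers in this assay. Compound 2 sits nearest to it, a 1.1-fold higher number from compound 2 to compound 3 (0.06 log units; within the scatter), a gap within the scatter, so the two compounds cannot be ordered. Compound 1 lies furthest from compound 3, and in this assay compound 1 gives 9.27 ug/mL against compound 3 with 29.2 ug/mL, a gap beyond the scatter.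

Compound 4 `COc1ccc(CN(C)c2nc(=O)c3cc(C(F)(F)F)cc([N+](=O)[O-])c3o2)cc1OC` differs from compound 3 in one place: methyl in place of hydrogen on a nitrogen on an aromatic ring. Among the compounds with values here, no measured step shows this change on its own. Compound 1 carries the same methyl on the same nitrogen, but also a different group on the saturated chain carbon, so its lower number cannot be assigned to the methyl alone. The only single-place step shown, from compound 2 to compound 3, concerns the aryl group and lies within the scatter, so it gives no direction for this change.

With compound 1 as the sole pointer, a modest drop toward a lower number in this assay is expected for compound 4, a 1.8-fold lower number from compound 3 to compound 4 (0.26 log units; within the scatter), while a result within the scatter of compound 3 remains plausible. The estimate for compound 4 is 16 ug/mL, with a range from 7 ug/mL to 32 ug/mL.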

Compound 4, half-maximal inhibitory concentration: 9.46 ug/mL
Estimate against measurement, compound 4: 1.7-fold (0.23 log units) above; measured number inside the range.
By their numbers in this assay, from the lowest: compounds 1 and 4 (each within the scatter of the next); then compounds 2 and 3 (each within the scatter of the next).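

In this assay, within the data shown here, methyl in place of hydrogen on a nitrogen on an aromatic ring can now be read as a change on its own, and it gives a 3.1-fold lower number from compound 3 to compound 4 (0.49 log units; beyond the scatter) as the first step at this nitrogen that lies beyond the scatter. With the methyl present, 3,4-dimethoxyphenyl in place of 2,3-dihydro-1,4-benzodioxin-6-yl on the saturated chain carbon gives no separation (a 1.0-fold higher number from compound 1 to compound 4 (0.01 log units; within the scatter)), just as the change of aryl group with hydrogen on the nitrogen stayed within the scatter (in a 1.1-fold higher number from compound 2 to compound 3 (0.06 log units; within the scatter)), so among these compounds only the change at the nitrogen moves the number beyond the scatter. No supporting measurement accompanies this result, so the step stands as an observation without an explanation.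

The compounds shown leave open whether an ethyl group, a longer chain or an acetyl group on the same nitrogen would give a similar step or a different one. They also leave open whether methyl gives the same step when the saturated chain carbon carries plain phenyl, as it does in compound 2.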